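Replacing sec-butyl with hydroxymethyl in compound 1

This account rests on a few compounds, and the source may have more. Where it says the series, first, only, none or still open, it means among the compounds named here.

Of the compounds shown here, three have values so far in a functional assay on MCF7 cells (Homo sapiens) for cytotoxicity, read by MTT assay, with a stated time of 24 h (a higher number here means a weaker inhibitor, a lower number a stronger inhibitor), and they read as follows.
Compound 1 `CC[C@H](C)[C@@H](NC(=O)Cn1cc(C2=C(c3c[nH]c4ccccc34)C(=O)N(C)C2=O)c2ccccc21)C(=O)OC` gives > 100000 nM here
Compound 2 `COC(=O)[C@@H](C)NC(=O)Cn1cc(C2=C(c3c[nH]c4ccccc34)C(=O)N(C)C2=O)c2ccccc21` gives 15300 nM here
Compound 3 `COC(=O)CCNC(=O)Cn1cc(C2=C(c3c[nH]c4ccccc34)C(=O)N(C)C2=O)c2ccccc21` gives 47800 nM here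

Compound 1 stands at the limit of > 100000 nM in this assay, at which 1 of the 3 values shown sits, and so has a limit rather than a number. Compound 4 `COC(=O)[C@@H](CO)NC(=O)Cn1cc(C2=C(c3c[nH]c4ccccc34)C(=O)N(C)C2=O)c2ccccc21` differs from compound 1 by hydroxymethyl in place of sec-butyl on a saturated chain carbon bound to an amide-type nitrogen and a carbonyl carbon on a saturated chain carbon bound to an amide-type nitrogen and a carbonyl carbon. Sec-butyl also leaves in the closest measured change, an at least 6.5-fold lower number from compound 1 to compound 2 (0.81 log units; beyond the scatter) and the change an at least 2.0-fold lower number from compound 1 to compound 3 (0.32 log units; beyond the scatter) runs the same way. A lower number of similar size is therefore expected, and the expected step is an at least 3.3-fold lower number from compound 1 to compound 4 (0.52 log units; beyond the scatter) in this assay as estimated here. Compound 4 is estimated at 30000 nM with a range from 9000 nM to 100000 nM as expected.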

Compound 4, half-maximal inhibitory concentration: 24500 nM
Compound 4: middle estimate off by 1.2-fold (0.09 log units), on the high side, within the range that was stated.
By their numbers in this assay, from the lowest: compounds 2, 4 and 3 (each within the scatter of the next, the first and the last beyond it). At a limit, above all of these: compound 1.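

Hydroxymethyl in place of sec-butyl gives a measurable number on this carbon (an at least 4.0-fold lower number from compound 1 to compound 4 (0.61 log units; beyond the scatter)), while hydroxy in place of hydrogen shows no difference beyond the scatter (a 1.6-fold higher number from compound 2 to compound 4 (0.20 log units; within the scatter)). The gap to the 2-(methoxycarbonyl)ethyl compound also stays within the scatter (a 2.0-fold lower number from compound 3 to compound 4 (0.29 log units; within the scatter)). The first step is only a bound, since compound 1 has a limit rather than a number in this assay: the limit of > 100000 nM in this assay, at which 1 of the 4 values shown sits. Still open, on these data alone, is how an amine or a carboxylic acid on this carbon would read. As far as these compounds go, a longer chain ending in hydroxy is equally open.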